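Ethyl to isopropyl on the chain

The compounds below may be only part of what the source reports. "The series", "measured", "known", "first", "only" and "open" are said of these compounds alone.

Among the measured compounds shown here, in an ADME assay on microsomes from liver (Homo sapiens) for metabolic stability (a lower number here means slower removal, a higher number faster removal of the compound), compound 3 (`CC[C@H](NC(=O)Cn1nnc2ccccc2c1=O)c1ccc(C)cc1`) gives 31 mL/min/kg as the only true number so far. Compound 1 (`C[C@@H](NC(=O)Cn1nnc2ccccc2c1=O)c1ccc(Cl)cc1`) reports < 9.9 mL/min/kg as a limit of the assay. Compound 2 (`Cc1ccc([C@H](C)NC(=O)Cn2nnc3ccccc3c2=O)cc1`) likewise reports < 9.9 mL/min/kg as a limit. Compound 4 (`Cc1ccc([C@@H](NC(=O)Cn2nnc3ccccc3c2=O)C(C)C)cc1`) differs from compound 3 by methyl in place of hydrogen on a saturated chain carbon bound to two saturated chain carbons (ethyl to isopropyl). For the measured compounds named here, one measured step bears on this: an at least 3.1-fold higher number from compound 2 to compound 3 (0.49 log units; beyond the scatter) is a rise beyond the scatter, and it too put methyl in place of hydrogen on a saturated chain carbon. Resting on that single step, a modest rise in this assay is expected, an estimated 1.6-fold higher number from compound 3 to compound 4 (0.21 log units; within the scatter) that may stay within the scatter. Compound 4 is expected at 50 mL/min/kg in clearance, with 22 mL/min/kg to 110 mL/min/kg as the estimated range.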

Compound 4, clearance: 34 mL/min/kg
Compound 4: middle estimate off by 1.5-fold (0.17 log units), on the high side; measured number inside the range.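

In this assay, ethyl and isopropyl on this chain carbon cannot be told apart, with a 1.1-fold higher number from compound 3 to compound 4 (0.04 log units; within the scatter). Replacing the methyl of compound 2 with isopropyl does lie beyond the scatter, with an at least 3.4-fold higher number from compound 2 to compound 4 (0.53 log units; beyond the scatter), so a larger group here separates from methyl, but the extra methyl on ethyl adds nothing measurable. The size of that larger step stays a bound, because compound 2 sits at a limit of the assay: the limit of < 9.9 mL/min/kg in this assay, at which 2 of the 4 values shown sit.

Going by these compounds, whether a longer chain such as butyl, or a chain carrying an amine, would behave like ethyl and isopropyl on this carbon remains open.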